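A few compounds are considered here, and "the series" means these few. Any claim that something is new, unique, unknown or untested is made for them only; others in the source may bear on it.

Of the compounds shown here, two of the same shared core have been tested in a functional assay on NCI-H23 cells (Homo sapiens) for inhibition, read by sulforhodamine B assay, with a stated time of 48 h; on this read-out higher numbers stand for lower toxicity in this test and lower numbers for higher toxicity in this test. Compound 1, with the structure `COc1cc2cc(Oc3ccc(NC(=O)Nc4cccc(C(F)(F)F)c4)cc3)c(C)nc2cc1OC`, reaches only the limit of this test: in this assay compound 1 gives > 50000 nM. Compound 2, with the structure `COc1cc2cc(Oc3ccc(NC(=O)Nc4ccc(Cl)c(C(F)(F)F)c4)cc3)c(C)nc2cc1OC`, carries one extra chloro group on the outer aromatic ring, and in this assay compound 2 gives 15800 nM. Within the data shown here, this is the only plain number in the set, the other value being a limit (the limit of > 50000 nM in this assay, at which 1 of the 2 values shown sits), so compound 2 is the only fixed point. Among the measured compounds shown here, the single measured step, an at least 3.1-fold lower number from compound 1 to compound 2 (0.50 log units; beyond the scatter), shows that a chloro group added there mattered.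

Compound 3, with the structure `COc1cc2cc(Oc3ccc(NC(=O)Nc4ccc(Cl)c(Cl)c4)cc3)c(C)nc2cc1OC`, differs from compound 2 by chloro in place of trifluoromethyl on an aromatic carbon. For the measured compounds named here, no measured step swaps one small group for another in this way, so the measured step only shows that compound 2 lies below the limit. For compound 3 the expected result in this assay is 20000 nM, between 7000 nM and 50000 nM. The expected change is a 1.3-fold higher number from compound 2 to compound 3 (0.10 log units; within the scatter), not beyond the scatter.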

Compound 3, concentration lethal to 50% of the cells: 76300 nM
Estimate against measurement, compound 3: 3.8-fold (0.58 log units) below; the whole stated range lies below it.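

Replacing trifluoromethyl with chloro on the outer ring in this assay gives a 4.8-fold higher number from compound 2 to compound 3 (0.68 log units; beyond the scatter), so the group at this position affects the result, and this swap moves towards lower toxicity in this test. Among these compounds, the earlier step showed only that adding a chloro group to that ring mattered, whereas this is the first measured exchange of one group for another on the ring, with a plain number at both ends. The step from compound 1 to compound 3 cannot be read because the value of compound 1 is a limit and not a number: the limit of > 50000 nM in this assay, at which 1 of the 3 values shown sits.

Going by these compounds, with only trifluoromethyl and chloro at this position, two groups cannot show whether the number follows the size of the group, and what a methoxy, a nitrile or an amine there would give remains open. On these data alone, whether the same swap would give a step of this size on a ring without the other chloro group also remains open.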